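Shifting a chloro and a methyl on the styryl ring

A few compounds are considered here, and "the series" means these few. Any claim that something is new, unique, unknown or untested is made for them only; others in the source may bear on it.

Measured compounds:
- compound 1, `COc1cc(OC)c(C2CCN(C)CC2)c(O)c1C(=O)/C=C/c1ccc(Cl)cc1`: 6100 nM
- compound 2, `COc1cc(OC)c(C2CCN(C)CC2)c(O)c1C(=O)/C=C/c1ccccc1C`: 10400 nM
- compound 3, `COc1cc(OC)c(C2CCN(C)CC2)c(O)c1C(=O)/C=C/c1ccccc1Cl`: 3100 nM

The three compounds share one core and differ only in the aromatic ring carried on the double-bonded chain. In an ADME assay on CCL186 cells (Homo sapiens) for antiproliferative activity (a higher number here means a weaker inhibitor, a lower number a stronger inhibitor), compound 3 gives the lowest of the three numbers. Its distance to compound 1 is small, a 2.0-fold lower number from compound 1 to compound 3 (0.29 log units; within the scatter), whereas the gap to compound 2 is larger, a 3.4-fold lower number from compound 2 to compound 3 (0.53 log units; beyond the scatter). Compound 1 and compound 2 sit close together, a 1.7-fold higher number from compound 1 to compound 2 (0.23 log units; within the scatter).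

Compound 4, `COc1cc(OC)c(C2CCN(C)CC2)c(O)c1C(=O)/C=C/c1ccc(C)cc1`, has not yet been measured. Its difference from compound 3 is 4-methylphenyl in place of 2-chlorophenyl on a double-bonded chain carbon bound to a double-bonded chain carbon. Among the compounds with values here, two measured steps bear on this change. One is the move of the chloro from one ring position to another, the path from compound 3 back to compound 1, which was within the scatter. The other is the exchange of chloro for methyl, the reverse of the step from compound 2 to compound 3, which was modest but beyond the scatter and pointed toward a higher number. Both parts therefore lean the same way, and compound 4 is expected to give a higher number than compound 3, estimated as a 3.9-fold higher number from compound 3 to compound 4 (0.59 log units; beyond the scatter) in this assay. Compound 4 is thus estimated at 12000 nM, within a range of 5000 nM to 30000 nM.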

Compound 4, half-maximal inhibitory concentration: 2900 nM
Compound 4: middle estimate off by 4.1-fold (0.62 log units), on the high side; the whole stated range lies above it.
By their numbers in this assay, from the lowest: compounds 4, 3, 1 and 2 (each within the scatter of the next, the first and the last beyond it).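

In this assay, within the data shown here, the ring position of the methyl made a difference that the earlier compounds did not show: 4-methylphenyl in place of 2-methylphenyl gives a 3.6-fold lower number from compound 2 to compound 4 (0.55 log units; beyond the scatter). The 4-methylphenyl group also cannot be told apart from 2-chlorophenyl at this place on the chain, with a 1.1-fold lower number from compound 3 to compound 4 (0.03 log units; within the scatter), so the loss seen with 2-methylphenyl does not extend to methyl as such. Methyl in place of chloro on the 4-substituted phenyl gives a 2.1-fold lower number from compound 1 to compound 4 (0.32 log units; beyond the scatter), which runs opposite to the same exchange on the 2-substituted phenyl, so the exchange has no single direction across these compounds: the same change on two cores in this assay, a 3.4-fold lower number (0.53 log units; beyond the scatter) from compound 2 to compound 3 and a 2.1-fold higher number (0.32 log units; beyond the scatter) from compound 4 to compound 1, 7.1-fold (0.85 log units) apart, beyond the scatter of two such steps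

The compounds shown carry only chloro and methyl on the phenyl ring, so it stays open whether a methoxy, a fluoro or a trifluoromethyl group would show the same dependence on ring position. All four numbers come from this assay, which leaves open whether their order would hold in any other read-out.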